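A few compounds are considered here, and "the series" means these few. Any claim that something is new, unique, unknown or untested is made for them only; others in the source may bear on it.

Compounds measured so far in a toxicity assay on NIH3T3 cells (Mus musculus) for cytotoxicity, read by resazurin assay; a lower number here means that less compound is needed, a higher number that more compound is needed for the effect:
- compound 1, `COC(=O)c1ccc(NCc2cncn2Cc2cccc([N+](=O)[O-])c2)cc1-c1ccccc1`: > 10000 nM
- compound 2, `COC(=O)c1ccc(NCc2cncn2Cc2ccc(-c3ccccc3)cc2)cc1-c1ccccc1`: > 1000 nM
- compound 3, `COC(=O)c1ccc(NCc2cncn2Cc2ccccc2F)cc1-c1ccccc1`: "not determined" (no result reported)

Three compounds share one core and differ only in the group on the saturated chain carbon bound to an aromatic nitrogen. In this assay compound 1 gives > 10000 nM, which is a limit of the assay rather than a number. Compound 2 gives > 1000 nM, again a limit. Compound 3 gives "not determined" (no result reported) in this assay, so no value of any kind stands for it. Two further values stand beside compound 3: the limit of > 10000 nM in this assay, at which 1 of the 3 values shown sits, and (the limit of > 1000 nM in this assay, at which 1 of the 3 values shown sits). Among the measured compounds shown here, the one computed step, a step that the two limits leave unreadable from compound 1 to compound 2, is therefore unreadable in size.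

Compound 4, `COC(=O)c1ccc(NCc2cncn2Cc2ccccc2C#N)cc1-c1ccccc1`, differs from compound 3 by cyano in place of fluoro on an aromatic carbon. For the measured compounds named here, no measured step shows a change of this kind, so nothing indicates the size or direction of any shift in this assay; what is known is only that compounds 1 and 2 both sit at limits. On that basis compound 4 is expected to sit at a limit as well, with an estimated value of 10000 nM and a range from 3000 nM to 50000 nM.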

Compound 4, half-maximal effective concentration: 25000 nM
The estimate for compound 4 lay 2.5-fold (0.40 log units) below the measured number, within the range that was stated.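

In this assay, no new step can be read for compound 4: compound 1 and compound 2 stand only at limits of the assay, and compound 3 has no number to compare. The compounds shown leave open how large a shift, and in which direction, cyano in place of fluoro brings.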